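Aryl swap on the quinoline core: compound 3 to compound 4

The source may report more compounds than this note shows. Statements on the series, on what has been measured and on what is new or still open speak of the compounds shown alone.

The series shares one core and is read in a functional assay on MKN-45 cells (Homo sapiens) for cytotoxicity, read by MTT assay, with a stated time of 72 h; a lower number here means a stronger inhibitor, a higher number a weaker inhibitor. Compound 1 `COc1cc2c(Oc3ccc(NC(=O)c4cc(-c5cccc(Cl)c5)nc5ccccc45)cc3F)ccnc2cc1OCCCN1CCCCC1` gives 11 nM in this assay. Compound 2 `COc1cc2c(Oc3ccc(NC(=O)c4cc(-c5ccc(Cl)c(Cl)c5)nc5ccccc45)cc3F)ccnc2cc1OCCCN1CCCCC1` gives 730 nM, and compound 3 `COc1cc2c(Oc3ccc(NC(=O)c4cc(-c5cccc(Cl)c5)nc5ccccc45)cc3F)ccnc2cc1OCCCN1CCC(C)CC1` gives 30 nM. On these three numbers compound 3 stands second highest, below compound 2 and above compound 1. The step of a 2.7-fold higher number from compound 1 to compound 3 (0.44 log units; beyond the scatter) was modest; the step of a 66-fold higher number from compound 1 to compound 2 (1.82 log units; beyond the scatter) was large, and it is the one that concerns the aryl group attached to the core.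

Compound 4 `COc1ccc(-c2cc(C(=O)Nc3ccc(Oc4ccnc5cc(OCCCN6CCC(C)CC6)c(OC)cc45)c(F)c3)c3ccccc3n2)cc1` is not yet measured. It differs from compound 3 in exactly that aryl group: 4-methoxyphenyl in place of 3-chlorophenyl on an aromatic carbon. For the measured compounds named here, the only step touching this group is the large one from compound 1 to compound 2, so a change here is expected to move the number well beyond the scatter; its direction is not fixed by the data, and the wider spread is carried in the range. The step of a 4.0-fold higher number from compound 3 to compound 4 (0.60 log units; beyond the scatter) is the expected outcome, because a 66-fold higher number from compound 1 to compound 2 (1.82 log units; beyond the scatter) shows this position to be sensitive. Compound 4 is therefore estimated at 120 nM, within 20 nM to 900 nM.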

Compound 4, half-maximal inhibitory concentration: 320 nM
The estimate for compound 4 lay 2.7-fold (0.43 log units) below the measured number, within the range that was stated.
By their numbers in this assay, from the lowest: compound 1; then compound 3; then compound 4; then compound 2.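

In this assay, replacing 3-chlorophenyl with 4-methoxyphenyl gives an 11-fold higher number from compound 3 to compound 4 (1.03 log units; beyond the scatter), so the sensitivity of this aryl group is not confined to the chloro addition seen in a 66-fold higher number from compound 1 to compound 2 (1.82 log units; beyond the scatter) and also appears with the methyl on the saturated ring. Both large steps at this group raise the number, and no change to it among the compounds shown lowers the number. No data bearing on the cause of this step are at hand.

The compounds shown leave open whether the rise follows the loss of the chlorine, the entry of the methoxy group, or the two together. A plain phenyl or a 3-methoxyphenyl at this carbon would help separate these readings, and a 4-chlorophenyl would test the chlorine on its own.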